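A few compounds are considered here, and "the series" means these few. Any claim that something is new, unique, unknown or untested is made for them only; others in the source may bear on it.

Measured compounds:

Compound 1, `COc1cc(F)cc(-c2ccc(C(=O)N(Cc3cccc(OCCCCCC(=O)O)c3)C(C)C)cc2)c1`: in an ADME assay on BJ cells (Homo sapiens) for cytotoxicity, read by CellTiter-Glo and resazurin assay, with a stated time of 72 h (on this read-out higher numbers stand for an effect only at larger amounts of compound and lower numbers for an effect already at smaller amounts), compound 1 gives > 26000 nM, which is a limit of the assay and not a number.

Compound 2, `CCOC(=O)CCCCCOc1cccc(CN(C(=O)c2ccc(-c3ccoc3)cc2)C(C)C)c1`: in this assay compound 2 gives > 26000 nM, again a limit of the assay rather than a number.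

Compound 2 therefore stands at the top of what was measured, and so does everything else shown: the limit of > 26000 nM in this assay, at which 2 of the 2 values shown sit. Within the data shown here, no step between two measured compounds is given, so there is nothing to say about how large a change of this kind has been in the past.

Compound 3, `CCOC(=O)CCCCCOc1cccc(CN(C(=O)c2ccc(-c3cc(F)cc(OC)c3)cc2)C(C)C)c1`, is built from compound 2 by one change: 3-fluoro-5-methoxyphenyl in place of furan-3-yl on an aromatic carbon. Compound 1 carries that same 3-fluoro-5-methoxyphenyl group and also sits at the limit in this assay. On that basis no step beyond the scatter is expected in this assay from compound 2 to compound 3; the step that the estimate implies is a step that the limit leaves unreadable from compound 2 to compound 3, and it is likely that only a limit will be reported again. Compound 3 is expected to give about 30000 nM, within a range of 15000 nM to 60000 nM.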

Compound 3, half-maximal effective concentration: > 26000 nM
Compound 3: only a limit was reported (the forecaster's own chance of this, stated with the estimate: 80%); the middle value is on the limit's open side.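

In this assay compound 3 gives > 26000 nM, again a limit of the assay and not a number. The steps to compound 3 from compound 1 and from compound 2 cannot be read, as all the values shown are limits: the limit of > 26000 nM in this assay, at which 3 of the 3 values shown sit.

The compounds shown leave open at what concentration, if any, these compounds would show an effect in this assay.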